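Fluoro for methyl on the 4-methylphenyl group

A few compounds are considered here, and "the series" means these few. Any claim that something is new, unique, unknown or untested is made for them only; others in the source may bear on it.

Compound 3 `Cc1ccc(-c2ccc(C)n2-c2ccc(-c3nc4ccc(F)cc4s3)cc2)cc1` gives 16700 nM in a functional assay on MDA-MB-231 cells (Homo sapiens) for cytotoxicity, read by MTT assay, with a stated time of 72 h; on this read-out higher numbers stand for weaker inhibition and lower numbers for stronger inhibition. Among the three measured compounds its number is the second highest: compound 1 `Cc1ccc(-c2ccc(C)n2-c2ccc(-c3nc4ccccc4s3)cc2)cc1` gives 17800 nM and compound 2 `Cc1ccc(-c2ccc(F)cc2)n1-c1ccc(-c2nc3ccccc3s2)cc1` gives 11800 nM, and the step of a 1.1-fold lower number from compound 1 to compound 3 (0.03 log units; within the scatter) as well as the gap to compound 2 lie within the scatter. Compound 4 `Cc1ccc(-c2ccc(F)cc2)n1-c1ccc(-c2nc3ccc(F)cc3s2)cc1` differs from compound 3 by fluoro in place of methyl on an aromatic carbon, the same difference, cut one bond further out, reading 4-methylphenyl to 4-fluorophenyl, para to a large group. The measured step that bears directly on this exchange is a 1.5-fold lower number from compound 1 to compound 2 (0.18 log units; within the scatter), the identical change made at the same place. The other step, a 1.1-fold lower number from compound 1 to compound 3 (0.03 log units; within the scatter), concerns fluoro entering on the core and is also within the scatter. Nothing measured in this series moves beyond the scatter, so for compound 4 in this assay a step of a 1.5-fold lower number from compound 3 to compound 4 (0.16 log units; within the scatter) is expected, a slightly lower number at most. Compound 4 is therefore estimated at 11500 nM, with a range from 5500 nM to 24000 nM.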

Compound 4, half-maximal inhibitory concentration: 14100 nM
Beside the measured number, compound 4's estimate is 1.2-fold (0.09 log units) below it; the range from low to high includes it.
By their numbers in this assay, from the lowest: compounds 2, 4, 3 and 1 (each within the scatter of the next).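

In this assay, 4-methylphenyl to 4-fluorophenyl on the fluorinated core gives a 1.2-fold lower number from compound 3 to compound 4 (0.07 log units; within the scatter) and so stays within the scatter on a second core, para to a large group: the same change on two cores in this assay, a 1.5-fold lower number (0.18 log units; within the scatter) from compound 1 to compound 2 and a 1.2-fold lower number (0.07 log units; within the scatter) from compound 3 to compound 4, 1.3-fold (0.11 log units) apart, within the scatter of two such steps. Fluoro in place of hydrogen on the core, read now with the 4-fluorophenyl group present, gives a 1.2-fold higher number from compound 2 to compound 4 (0.08 log units; within the scatter) and also stays within the scatter: the same change on two cores in this assay, a 1.1-fold lower number (0.03 log units; within the scatter) from compound 1 to compound 3 and a 1.2-fold higher number (0.08 log units; within the scatter) from compound 2 to compound 4, 1.3-fold (0.11 log units) apart, within the scatter of two such steps. Neither change separates the compounds on either core, and no dependence of one change on the other can be read.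

As far as these compounds go, whether this position responds to anything other than methyl or fluoro remains open; an amine, a carboxylic acid or a longer chain there would test it. The same question stands on the core, where only hydrogen and fluoro are shown.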